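A few compounds are considered here, and "the series" means these few. Any claim that something is new, unique, unknown or untested is made for them only; others in the source may bear on it.

Compound 1, `Cc1cc2c(cc1C(=O)N=C(N)N)S(=O)(=O)CCC2C`: in an assay on cells for inhibition of sodium/hydrogen exchanger (Oryctolagus cuniculus) (a higher number here means a weaker inhibitor, a lower number a stronger inhibitor), compound 1 gives 45 nM.
Compound 2, `CCC1(O)CS(=O)(=O)c2cc(C(=O)N=C(N)N)c(C)cc21`: in this assay compound 2 gives 34 nM.

Compound 2 holds the lower of the two numbers, yet compound 1 sits within the scatter of it, so no order between the two is claimed. Compound 3, `Cc1cc2c(cc1C(=O)N=C(N)N)S(=O)(=O)CC2(O)C(=O)c1ccccc1`, is still to be measured in this assay. It differs from compound 2 in one place: benzoyl in place of ethyl on a saturated ring carbon. Within the data shown here, no measured pair shows a change of this kind, so the size of the step is unknown; a modest move toward a higher number is expected, a 1.8-fold higher number from compound 2 to compound 3 (0.25 log units; within the scatter), though the uncertainty is wide. For compound 3 the expected value in this assay is 60 nM, within a range from 15 nM to 250 nM.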

Compound 3, half-maximal inhibitory concentration: 43 nM
For compound 3 the middle estimate is 1.4-fold (0.14 log units) above the measured one; the range from low to high includes it.
By their numbers in this assay, from the lowest: compounds 2, 3 and 1 (each within the scatter of the next).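

Benzoyl in place of ethyl on the saturated ring carbon, two ring bonds from the ring sulfur, gives a 1.3-fold higher number from compound 2 to compound 3 (0.10 log units; within the scatter) in this assay. This position therefore carries a six-membered aromatic ring and a carbonyl, as well as ethyl, without separating the two compounds in this read-out. Nothing on hand accounts for the size of this step.
Still open, from the compounds shown here alone, is whether an amine, a carboxylic acid or a longer alkyl chain on this carbon would keep the number in the same range. A single pair also cannot show how far this tolerance extends across other groups.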